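The compounds below may be only part of what the source reports. "The series", "measured", "known", "first", "only" and "open" are said of these compounds alone.

Of the compounds shown here, three built on one shared core have been measured in a functional assay on HGC-27 cells (Homo sapiens) for cytotoxicity, read by MTT assay, with a stated time of 72 h; on this read-out lower numbers stand for stronger inhibition and higher numbers for weaker inhibition. Compound 1, `FC(F)(F)c1ccc(CSc2nc(Nc3ccccc3Cl)c3ccccc3n2)cc1`, carries a 2-chlorophenyl on a nitrogen of the core; in this assay compound 1 gives > 50000 nM, which is a limit of the assay rather than a number. Compound 2, `O=[N+]([O-])c1cccc(Nc2nc(SCc3ccc(C(F)(F)F)cc3)nc3ccccc23)c1`, carries a 3-nitrophenyl at the same place; in this assay compound 2 gives > 50000 nM, again a limit and not a number. Compound 3, `Fc1ccc(Nc2nc(SCc3ccc(C(F)(F)F)cc3)nc3ccccc23)cc1`, carries a 4-fluorophenyl there, and in this assay compound 3 gives 19500 nM. Among the three results this is the only actual number, the other two sitting at the limit described as the limit of > 50000 nM in this assay, at which 2 of the 3 values shown sit. The step of an at least 2.5-fold lower number from compound 1 to compound 3 (0.40 log units; beyond the scatter) and the step of an at least 2.5-fold lower number from compound 2 to compound 3 (0.40 log units; beyond the scatter) both lie beyond the scatter, so the ring on that nitrogen does move the read-out. Compound 4, `COc1ccc(Nc2nc(SCc3ccc(C(F)(F)F)cc3)nc3ccccc23)c(OC)c1`, is not yet measured; it differs from compound 3 by 2,4-dimethoxyphenyl in place of 4-fluorophenyl on a nitrogen on an aromatic ring. Among the measured compounds shown here, no measured step involves a methoxy group, so the size of this change is open; the two measured steps show only that a different ring at this place can shift the number at least modestly. The expected step is therefore a 1.3-fold higher number from compound 3 to compound 4 (0.11 log units; within the scatter) in this assay. The estimate for compound 4 is 25000 nM, within a range from 7000 nM to 60000 nM.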

Compound 4, half-maximal inhibitory concentration: > 50000 nM
Compound 4 gave a limit, no number; the forecaster's own chance of this, stated with the estimate: 40%; middle value at least 2.0-fold (0.30 log units) from the limit.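

In this assay, putting 2,4-dimethoxyphenyl in place of 4-fluorophenyl on the nitrogen gives an at least 2.5-fold higher number from compound 3 to compound 4 (0.40 log units; beyond the scatter), so this change moves the read-out towards weaker inhibition, and by more than repeated measurements would scatter. Among the compounds shown here, this is the first measured step at this place that brings in methoxy groups, and with it compound 4 joins compound 1 and compound 2, leaving the 4-fluorophenyl of compound 3 as the only ring here that yields an actual number: the limit of > 50000 nM in this assay, at which 3 of the 4 values shown sit. The steps linking compound 4 to compound 1 and to compound 2 cannot be read, since each pair consists of two limits.

Going by these compounds, whether a single methoxy group on the ring would give the same result as the two in compound 4 remains open. Also open, on these data alone, is whether any other ring on this nitrogen, such as a plain phenyl or a phenyl carrying an amine or a carboxylic acid, would give a lower number in this assay than compound 3 with its 19500 nM.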